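This account rests on a few compounds, and the source may have more. Where it says the series, first, only, none or still open, it means among the compounds named here.

In a functional assay on the whole organism with Canis familiaris (Canis lupus familiaris) as the target (a higher number here means that more compound is needed for the effect, a lower number that less compound is needed), compound 1 `Cc1cccc(-c2nc3cc[nH]cc-3n2)c1` gives 1 mg/kg and compound 2 `COc1ccc(-c2nc3cc[nH]cc-3n2)cc1` gives 1.7 mg/kg on the same scale. Compound 3 `COc1ccc(-c2nc3cc[nH]cc-3n2)c(OC)c1` stands at 0.3 mg/kg and holds the lowest number of the three.

Compound 4 `COc1cc([N+](=O)[O-])ccc1-c1nc2cc[nH]cc-2n1` is not yet measured. It differs from compound 3 by nitro in place of methoxy on an aromatic carbon, meta to a methoxy group nitro in place of methoxy on an aromatic carbon and the other methoxy stays in place.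

For the measured compounds named here, the only measured step within this set is a 5.7-fold lower number from compound 2 to compound 3 (0.75 log units; beyond the scatter) and it adds a methoxy rather than exchanging one, so it is a loose guide. Going by the values given here, no measured compound carries nitro.

Among the compounds with values here, with that step as the only guide to size, a modest move toward a higher number is expected in this assay and its direction remains uncertain. The expected change is a 2.7-fold higher number from compound 3 to compound 4 (0.43 log units; beyond the scatter) as a working estimate. Compound 4 is estimated at 0.8 mg/kg with 0.2 mg/kg to 3 mg/kg as its expected range.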

Compound 4, dose for half-maximal effect: 0.015 mg/kg
Compound 4: the middle estimate sits 53-fold (1.73 log units) above what was measured; the measured number lies below the stated range.
By their numbers in this assay, from the lowest: compound 4; then compound 3; then compounds 1 and 2 (each within the scatter of the next).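

In this assay, for the compounds shown here, nitro in place of methoxy gives a 20-fold lower number from compound 3 to compound 4 (1.30 log units; beyond the scatter) and is the largest step so far, larger than a 5.7-fold lower number from compound 2 to compound 3 (0.75 log units; beyond the scatter) which changed a different place on the ring. Going by these compounds alone, the methoxy para to the group of 9 heavy atoms is therefore not needed for a low number in this pair, and the replacement with nitro moves compound 4 well past compound 3, something the earlier compounds could not show since all of their changes left this exchange untested. Nothing available gives a measured basis for explaining the size of this step.

On these data alone, whether an amine, a nitrile or a carboxylic acid in the same place would give a similarly low number remains open. Also open, as far as these compounds go, is how much the remaining methoxy contributes once nitro is present.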